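Swapping methoxy for bromo on a hepatoma cell assay

This account rests on a few compounds, and the source may have more. Where it says the series, first, only, none or still open, it means among the compounds named here.

Of the compounds shown here, three have so far been tested in a functional assay on HepG2 cells (Homo sapiens) for antiproliferative activity, read by MTT assay, with a stated time of 72 h; a higher number here means a weaker inhibitor, a lower number a stronger inhibitor. Compound 1 `CCOC(=O)c1csc2nc(CN3CCN(C)CC3)c(-c3ccc(OC)cc3)n12` gives 68400 nM in this assay. Compound 2 `CCOC(=O)c1csc2nc(CN3CCN(C)CC3)c(-c3ccc(Br)cc3)n12` differs from compound 1 in one place only, (bromo in place of methoxy on an aromatic carbon), and in this assay compound 2 gives 82700 nM. Compound 3 `COc1ccc(-c2cnc3scc(C(=O)NNC(C)=O)n23)cc1` is built on a different core; the difference between the two cores is not broken down here. In this assay compound 3 gives 11800 nM, the lowest of the three numbers, and its gap to compound 1 and to compound 2 lies beyond the usual scatter of this kind of measurement.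

Compound 4 `CC(=O)NNC(=O)c1csc2ncc(-c3ccc(Br)cc3)n12` has not yet been measured. Among the compounds with values here, it differs from compound 3 by bromo in place of methoxy on an aromatic carbon, which is the same change at the same kind of place as the one between compound 1 and compound 2. Within the data shown here, the only measured example of this change, a 1.2-fold higher number from compound 1 to compound 2 (0.08 log units; within the scatter), stayed within the scatter, so the change did not move the number in a meaningful way there. A step of similar size is therefore expected here: a 1.2-fold higher number from compound 3 to compound 4 (0.07 log units; within the scatter). Among the measured compounds shown here, compound 4 is expected to give about 14000 nM in this assay, with the number most likely falling between 7000 nM and 28000 nM, because the measured step of a 1.2-fold higher number from compound 1 to compound 2 (0.08 log units; within the scatter) gives the one available guide to this change.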

Compound 4, half-maximal inhibitory concentration: 3480 nM
Compound 4: the middle estimate sits 4.0-fold (0.60 log units) above what was measured; the measured number lies below the stated range.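

In this assay, putting bromo in place of methoxy on an aromatic carbon gives a 3.4-fold lower number from compound 3 to compound 4 (0.53 log units; beyond the scatter), so on this core the swap moves the number beyond the usual scatter, while on the core of compound 1 the same swap did not. The two steps do not agree, which means that the size of this change, read on one core, cannot simply be carried over to the other core in this series: the same change on two cores in this assay, a 1.2-fold higher number (0.08 log units; within the scatter) from compound 1 to compound 2 and a 3.4-fold lower number (0.53 log units; beyond the scatter) from compound 3 to compound 4, 4.1-fold (0.61 log units) apart, beyond the scatter of two such steps. The comparison rests on a single pair of compounds on each core, so it does not show which feature of the cores sets the two steps apart, nor how the swap would behave on a third core.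

The compounds shown leave open whether another group on the same aromatic carbon, such as chloro, trifluoromethyl or an amine, would follow the pattern of bromo on either core. They also leave open whether the swap would give a step closer to the small one or the larger one on a core carrying a carboxylic acid in place of the ethyl ester of compound 1.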